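The source may hold more compounds than are shown below. What is called first, only, known or untested is meant among the compounds shown, and "the series" means these compounds.

Compound 1, `CCOC(=O)CN(Cc1ccccc1)c1nc(NCc2cccc(OC)c2)ncc1[N+](=O)[O-]`: in a functional assay on A549 cells (Homo sapiens) for antiproliferative activity, read by MTT assay, with a stated time of 48 h (a higher number here means a weaker inhibitor, a lower number a stronger inhibitor), compound 1 gives only the assay limit, > 100000 nM.
Compound 2, `COC(=O)CN(C)c1nc(Nc2ccc(Cl)cc2)ncc1[N+](=O)[O-]`: in this assay compound 2 gives 23500 nM.
Compound 3, `CCOC(=O)CNc1nc(Nc2ccc(Cl)cc2)ncc1[N+](=O)[O-]`: in this assay compound 3 gives only the assay limit, > 100000 nM.

Compound 1 stands at the limit, (the limit of > 100000 nM in this assay, at which 2 of the 3 values shown sit), so no number is known for it. Within the data shown here, the single measured step, an at least 4.2-fold higher number from compound 2 to compound 3 (0.62 log units; beyond the scatter), changes the nitrogen carrying the ester chain and the size of its ester, not the other amino substituent, and so does not bear on the change considered here. Compound 4, `CCOC(=O)CN(Cc1ccccc1)c1nc(Nc2cccc(OC)c2)ncc1[N+](=O)[O-]`, differs from compound 1 by 3-methoxyphenyl in place of 3-methoxybenzyl on a nitrogen on an aromatic ring. Among the measured compounds shown here, no measured pair carries this change, and compounds 2 and 3 show that the anilino variants can fall either side of the limit. Compound 4 is therefore expected near the limit, estimated at 60000 nM (range 15000 nM to 200000 nM), which means an expected at least 1.6-fold lower number from compound 1 to compound 4 (0.22 log units; that floor lies within the scatter).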

Compound 4, half-maximal inhibitory concentration: > 100000 nM
Compound 4: only a limit was reported (the forecaster's own chance of this, stated with the estimate: 50%); at least 1.6-fold (0.22 log units) between middle value and limit.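

Compound 1 and compound 4 both stand at the limit, so the change from 3-methoxybenzyl to 3-methoxyphenyl gives no readable step: the limit of > 100000 nM in this assay, at which 3 of the 4 values shown sit.

The compounds shown leave open whether this change alters activity at all in this assay.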